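Swapping the outer ring pair: from two nitrogens to sulfur

This account rests on a few compounds, and the source may have more. Where it says the series, first, only, none or still open, it means among the compounds named here.

Measured compounds:
compound 1, `CC(=O)N1CCC(n2cc(-c3cnc(N)c4oc(-c5cnc6cnccn56)cc34)cn2)CC1`, 0.52
compound 2, `CC(=O)N1CCC(n2cc(-c3cnc(N)c4oc(-c5cn(C)c6cnccc56)cc34)cn2)CC1`, 0.91

The two measured compounds share one core and differ only in the ring pair attached to it. In an ADME assay on microsomes from liver (Mus musculus) for metabolic stability (a lower number here means that the liver removes a smaller share, a higher number that the liver removes a larger share of the compound in one pass), compound 2 gives the higher of the two numbers, and the step between them is a number 0.39 higher from compound 1 to compound 2 (beyond the scatter), a large step.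

Compound 3, `CC(=O)N1CCC(n2cc(-c3cnc(N)c4oc(-c5csc6ccccc56)cc34)cn2)CC1`, has not yet been measured. It changes compound 2 as follows: a group of 9 heavy atoms (8 carbon, 1 sulfur; one five-membered aromatic ring with 1 hetero atom, one six-membered aromatic ring of carbon only) in place of a group of 10 heavy atoms (8 carbon, 2 nitrogen; one five-membered aromatic ring with 1 hetero atom, one six-membered aromatic ring with 1 hetero atom), on an aromatic carbon.

For the measured compounds named here, only one measured step exists, and it bears on this change loosely: it exchanged one outer ring pair for another and moved the number by a number 0.39 higher from compound 1 to compound 2 (beyond the scatter). The step from compound 2 to compound 3 again exchanges the outer ring pair, and compound 2 already stands high. A further rise is expected, but a small one, since the number of compound 2 leaves little room. The estimated step is a number 0.030 higher from compound 2 to compound 3 (within the scatter). Compound 3 is therefore expected to give about 0.94 in this assay, between 0.84 and 0.99.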

Compound 3, hepatic extraction ratio: 0.85
Compound 3: middle estimate off by 0.090, on the high side, and the stated range covers the measured number.
By their numbers in this assay, from the lowest: compound 1; then compounds 3 and 2 (each within the scatter of the next).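

In this assay, putting the 1-benzothiophen-3-yl group on the aromatic carbon next to the ring oxygen gives a number 0.060 lower from compound 2 to compound 3 (within the scatter), so this second exchange of the outer ring pair does not separate compound 3 from compound 2. Set against the ring pair of compound 1, the same group gives a number 0.33 higher from compound 1 to compound 3 (beyond the scatter), which stands beside the earlier a number 0.39 higher from compound 1 to compound 2 (beyond the scatter) as a second large step in the same direction. Among these three compounds, then, only compound 1 sits apart, and a high number does not require the nitrogen atoms of the group in compound 2, as the 1-benzothiophen-3-yl group carries none. Nothing available here explains why the numbers fall this way.

The three compounds leave open which feature of the ring pair of compound 1 goes with its lower number, as that pair differs from the other two in more than one respect. They also leave open whether an amine or a carboxylic acid on the 1-benzothiophen-3-yl group would bring the number down towards that of compound 1.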